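Chloro in Place of Bromo: From Compound 2 to Compound 3

This account rests on a few compounds, and the source may have more. Where it says the series, first, only, none or still open, it means among the compounds named here.

The read-out here comes from a physicochemical assay, read by spectrophotometry, with a stated time of 20 min, tested at 100 uM; on this read-out lower numbers stand for less inhibition and higher numbers for more inhibition at the one concentration tested (going by the name of the read-out). Of the compounds shown here, two carry numbers so far. Compound 1, `O=c1oc2ccc(Br)cc2cc1-c1ccc(O)c(O)c1`, gives 78% in this assay. Compound 2, `COc1ccc(-c2c(C)c3cc(Br)ccc3oc2=S)cc1OC`, gives 26% in this assay, the lowest of the two numbers, and compound 1 stands higher by a gap beyond the usual scatter. Among the compounds with values here, no pair of measured compounds differs in only one place, so no single change has yet been tied to a shift in this assay.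

Compound 3, `COc1ccc(-c2c(C)c3cc(Cl)ccc3oc2=S)cc1OC`, has not been measured. Compared with compound 2 it shows (chloro in place of bromo on an aromatic carbon). Because compound 2 gives 26% and the two halogens are exchanged one for one with nothing else altered, the step of a number 3 percentage points lower from compound 2 to compound 3 (within the scatter) is expected to stay within the scatter, with no clear direction. Compound 3 is therefore estimated at 23%, within a range from 5% to 45%.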

Compound 3, a percentage reported as inhibition, at one concentration (the size of the read-out at that concentration, not a potency): "not active" (no number reported)
The entry for compound 3 holds no number; the estimate stays without a comparison.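

In this assay, within the data shown here, compound 3 is recorded as "not active" without a number, so no step from compound 2 to compound 3 can be read. No supporting data bear on this result. The compounds shown leave open whether chloro in place of bromo shifts the read-out at all.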